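Capping the Acid of Compound 2 with a Methoxyazetidine Amide

The source may hold more compounds than are shown below. What is called first, only, known or untested is meant among the compounds shown, and "the series" means these compounds.

Measured compounds:
compound 1 `CCOC(=O)/C=C/c1ccncc1-c1ccc2ccccc2c1` gives 53.3 nM
compound 2 `O=C(O)/C=C/c1ccncc1-c1ccc2ccccc2c1` gives 5 nM

In an assay on a protein complex for inhibition of CDK8/Cyclin C (Homo sapiens), with a stated time of 1 h (a lower number here means a stronger inhibitor, a higher number a weaker inhibitor), compound 2 stands at the lowest number of the two measured; its nearest neighbour is compound 1, and the step of an 11-fold lower number from compound 1 to compound 2 (1.03 log units; beyond the scatter) shows how far apart they lie. Compound 3 `COC1CN(C(=O)/C=C/c2ccncc2-c2ccc3ccccc3c2)C1` is not yet measured. It differs from compound 2 by 3-methoxyazetidin-1-yl in place of hydroxy on a carbonyl carbon. Going by the values given here, the only measured step that bears on this change is an 11-fold lower number from compound 1 to compound 2 (1.03 log units; beyond the scatter), which shows that replacing the acid hydrogen with a group on the same oxygen raised the number considerably. Compound 3 likewise removes the acid hydrogen and adds a larger group at the carbonyl, so a higher number is expected, roughly of the size seen from the ester. Compound 3 is therefore estimated at 35 nM, with a range of 8 nM to 150 nM, an expected step of a 7.0-fold higher number from compound 2 to compound 3 (0.85 log units; beyond the scatter).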

Compound 3, half-maximal inhibitory concentration: 42.8 nM
Compound 3: the middle estimate sits 1.2-fold (0.09 log units) below what was measured; the measured number falls inside the stated range.
By their numbers in this assay, from the lowest: compound 2; then compounds 3 and 1 (each within the scatter of the next).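

In this assay, an 8.6-fold higher number from compound 2 to compound 3 (0.93 log units; beyond the scatter) shows that an amide at this carbonyl carbon, like the ester, does not keep the low number of the free acid. The further comparison, a 1.2-fold lower number from compound 1 to compound 3 (0.10 log units; within the scatter), shows that 3-methoxyazetidin-1-yl and ethoxy cannot be told apart here, although only the former brings a four-membered ring. Among these three compounds, only compound 2, with hydroxy in this place, reaches the low number, and none goes against that pattern. No available evidence explains the gap between the acid and the two capped compounds. Still open, from the compounds shown here alone, is whether a tetrazole could stand in for the carboxylic acid, and whether a simple dimethylamine amide or an unsubstituted azetidine amide would give a number different from compound 3.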